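Adding a Third Methoxy Group to a Weak Growth Inhibitor

This account rests on a few compounds, and the source may have more. Where it says the series, first, only, none or still open, it means among the compounds named here.

Measured so far:
compound 1, `Nc1cc(N)c2nc(-c3ccccc3)c(NCc3ccc(Cl)c(Cl)c3)nc2c1` — 12900 nM
compound 2, `COc1ccc(CNc2nc3cc(N)cc(N)c3nc2-c2ccccc2)cc1OC` — 16600 nM

Both compounds share one core and differ only in the aryl group on the saturated carbon attached to the ring nitrogen. In a functional assay on TK-10 cells (Homo sapiens) for inhibition, read by sulforhodamine B assay, with a stated time of 48 h (on this read-out higher numbers stand for weaker inhibition of growth and lower numbers for stronger inhibition of growth), compound 2 gives 16600 nM, the highest of the two numbers, while compound 1 gives 12900 nM; the change a 1.3-fold higher number from compound 1 to compound 2 (0.11 log units; within the scatter) sits within the scatter, so the two cannot be told apart.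

Compound 3, `COc1cc(CNc2nc3cc(N)cc(N)c3nc2-c2ccccc2)cc(OC)c1OC`, has not yet been measured. It differs from compound 2 by methoxy in place of hydrogen on an aromatic carbon. Among the compounds with values here, the only step that bears on this change, the one from compound 1 to compound 2, was within the scatter despite a larger swap of substituents. On that basis no step beyond the scatter in this assay is expected; the expected change is a 1.1-fold higher number from compound 2 to compound 3 (0.04 log units; within the scatter). Compound 3 is therefore estimated at 18000 nM, with a range from 7000 nM to 45000 nM.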

Compound 3, concentration for 50% growth inhibition: 6310 nM
Compound 3: the middle estimate sits 2.9-fold (0.46 log units) above what was measured, and the stated range ends above it.
By their numbers in this assay, from the lowest: compound 3; then compounds 1 and 2 (each within the scatter of the next).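

In this assay methoxy in place of hydrogen gives a 2.6-fold lower number from compound 2 to compound 3 (0.42 log units; beyond the scatter), the only step among these compounds that lies beyond the scatter. The earlier change of the whole aryl substitution, from 3,4-dichlorophenyl to 3,4-dimethoxyphenyl, could not be told from the scatter, whereas this one small addition, on an aromatic carbon ortho to a methoxy group and meta to a large group, can, so the aromatic ring does respond to what is placed on it. Nothing shown here accounts for the step.

Going by these compounds, it remains open whether the step belongs to methoxy in particular or would also appear with a hydroxy group, an ethoxy group or an amine on that same aromatic carbon. A single step also cannot show whether the same change would act alike on the 3,4-dichlorophenyl compound.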